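Selenocyanate carbamates: swapping benzyl for butyl

This account rests on a few compounds, and the source may have more. Where it says the series, first, only, none or still open, it means among the compounds named here.

Measured compounds:
- compound 1 `N#C[Se]c1ccc(NC(=O)OCc2ccc([N+](=O)[O-])cc2)cc1`: 11800 nM
- compound 2 `N#C[Se]c1ccc(NC(=O)OCc2ccccc2)cc1`: 8700 nM

Compound 1 and compound 2 share a core carrying a selenocyanate and a carbamate. In a functional assay on MCF7 cells (Homo sapiens) for cytotoxicity, read by MTT assay, with a stated time of 72 h (a lower number here means a stronger inhibitor of growth, a higher number a weaker inhibitor of growth), compound 1 gives 11800 nM and compound 2 gives 8700 nM. Going by the values given here, the one step between them, a 1.4-fold lower number from compound 1 to compound 2 (0.13 log units; within the scatter), shows that the two numbers cannot be told apart. Compound 2 therefore holds the lower of the two numbers, but only within the scatter of compound 1.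

Compound 3 `CCCCOC(=O)Nc1ccc([Se]C#N)cc1` differs from compound 2 in another place: propyl in place of phenyl on a saturated chain carbon bound to an oxygen next to a carbonyl group. Among the compounds with values here, no measured step touches this part of the molecule; the only step known, a 1.4-fold lower number from compound 1 to compound 2 (0.13 log units; within the scatter), changes a group on the phenyl that is now removed altogether. There is thus no direct guide, and the record so far shows a core that tolerates a change at the far end without moving in this assay. On that basis compound 3 is expected to sit close to compound 2, with a 1.1-fold higher number from compound 2 to compound 3 (0.06 log units; within the scatter) as the anticipated step and no shift beyond the scatter. The estimate for compound 3 in this assay is 10000 nM, within a range from 4000 nM to 25000 nM.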

Compound 3, concentration for 50% growth inhibition in the MCF7 assay: 6600 nM
Compound 3: middle estimate off by 1.5-fold (0.18 log units), on the high side; low and high end bracket the measured number.
By their numbers in the MCF7 assay, from the lowest: compounds 3, 2 and 1 (each within the scatter of the next).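

In the MCF7 assay the change of phenyl to propyl, on a saturated chain carbon bound to an oxygen next to a carbonyl group, gives a 1.3-fold lower number from compound 2 to compound 3 (0.12 log units; within the scatter) and so leaves no difference that can be told apart. The earlier step only altered a group on the phenyl, whereas this one shows that for these two compounds the whole six-membered aromatic ring can give way to an open chain without a readable change in the cell result. In a physicochemical assay, with a stated time of 180 min, tested at 0.5 mg/mL (a higher number here means more inhibition at the concentration tested (going by the name of the read-out), a lower number less inhibition), compound 2 gives 3.7% and compound 3 gives 6.6%, and a number 2.9 percentage points higher from compound 2 to compound 3 (within the scatter) likewise separates nothing; no evidence at hand offers any explanation for either result.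

What the compounds shown leave open is whether the numbers would stay level for a longer chain, an amine or a carboxylic acid at the same place, as phenyl and propyl alone cannot settle this. Since compound 1, compound 2 and compound 3 all keep the selenocyanate and the carbamate, they also leave open how much of the growth inhibition depends on either of these parts.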